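From pyrrolidin-2-yl to piperidin-3-yl on the shared core

The compounds below may be only part of what the source reports. "The series", "measured", "known", "first", "only" and "open" are said of these compounds alone.

In a functional assay on A-375 cells (Homo sapiens) for inhibition, read by MTT assay, with a stated time of 5 days (a higher number here means a weaker inhibitor, a lower number a stronger inhibitor), compound 2 (`Nc1nccc(-c2sc(C3CCCN3)nc2-c2cccc(NS(=O)(=O)c3cc(F)ccc3F)c2F)n1`) gives 11.2 nM and is the second highest of three numbers, with a higher number for compound 1 (`Nc1nccc(-c2sc(C3CCN3)nc2-c2cccc(NS(=O)(=O)c3cc(F)ccc3F)c2F)n1`) at 32.8 nM and a lower number for compound 3 (`CC(C)(C)c1nc(-c2cc(Cl)cc(NS(=O)(=O)c3cc(F)ccc3F)c2F)c(-c2ccnc(N)n2)s1`) at 1.73 nM. Compound 4 (`Nc1nccc(-c2sc(C3CCCNC3)nc2-c2cccc(NS(=O)(=O)c3cc(F)ccc3F)c2F)n1`) has piperidin-3-yl in place of pyrrolidin-2-yl on an aromatic carbon. Among the measured compounds shown here, one measured step bears on this change: pyrrolidin-2-yl in place of azetidin-2-yl gave a 2.9-fold lower number from compound 1 to compound 2 (0.47 log units; beyond the scatter) and was modest. For the measured compounds named here, no measured compound carries piperidin-3-yl, so that step is only a weak guide. In this assay the expected step is small, a 1.2-fold lower number from compound 2 to compound 4 (0.09 log units; within the scatter) and probably none beyond the scatter. For compound 4 the estimated value is 9 nM with an expected range of 3 nM to 30 nM here.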

Compound 4, half-maximal inhibitory concentration: 44.1 nM
Beside the measured number, compound 4's estimate is 4.9-fold (0.69 log units) below it; measured number outside the range, above it.
By their numbers in this assay, from the lowest: compound 3; then compound 2; then compounds 1 and 4 (each within the scatter of the next).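

In this assay piperidin-3-yl in place of pyrrolidin-2-yl brought a 3.9-fold higher number from compound 2 to compound 4 (0.60 log units; beyond the scatter) and so ran opposite to the earlier step from azetidin-2-yl to pyrrolidin-2-yl. Piperidin-3-yl in place of azetidin-2-yl brought a 1.3-fold higher number from compound 1 to compound 4 (0.13 log units; within the scatter) so that, among these three groups on this aromatic carbon, only pyrrolidin-2-yl stands apart. No evidence on the reason for this is available.

On these data alone, what stays open is whether the rise follows the larger ring or the point at which it is attached. Piperidin-2-yl, piperidin-4-yl or an open-chain amine on the same carbon would bear on that question.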